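The source may hold more compounds than are shown below. What is called first, only, known or untested is meant among the compounds shown, and "the series" means these compounds.

The study compares three measured compounds and one not yet measured. Compound 1 `COC(=O)c1cc(CCc2cc(C(C)=O)ccc2OC)ccc1O` was tested in a functional assay on HaCaT cells (Homo sapiens) for antiproliferative activity, read by sulforhodamine B assay, with a stated time of 3 days (on this read-out higher numbers stand for weaker inhibition and lower numbers for stronger inhibition), where compound 1 gives 660 nM. Compound 2 `COC(=O)c1cc(CCc2cc(OC)ccc2C(C)=O)ccc1O` has the same atoms joined differently; the difference between the two cores is not broken down here. In this assay compound 2 gives 41 nM, and compound 3 `CCc1ccc(OC)cc1CCc1ccc(O)c(C(=O)OC)c1` gives 130 nM. Compound 1 thus stands highest of the three, with compound 3 nearest and compound 2 furthest.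

The change from compound 2 to compound 3 is ethyl in place of acetyl on an aromatic carbon, and it made a 3.2-fold higher number from compound 2 to compound 3 (0.50 log units; beyond the scatter). The same kind of change leads from compound 1 to the unmeasured compound 4 `CCc1ccc(OC)c(CCc2ccc(O)c(C(=O)OC)c2)c1`: ethyl in place of acetyl on an aromatic carbon. The two places are not the same word for word: in compound 2 the acetyl sits ortho to a large group, whereas in compound 1 it sits meta to a large group; in both it is para to a methoxy group.

Because the step of a 3.2-fold higher number from compound 2 to compound 3 (0.50 log units; beyond the scatter) was modest and beyond the scatter, a step of similar size and direction is expected for compound 4, though the different surroundings of the place leave more room for deviation. The step expected here is a 2.7-fold higher number from compound 1 to compound 4 (0.44 log units; beyond the scatter). Compound 4 is thus estimated at 1800 nM in this assay, with an expected range from 600 nM to 6000 nM.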

Compound 4, half-maximal inhibitory concentration: 430 nM
Compound 4: middle estimate off by 4.2-fold (0.62 log units), on the high side; measured number below the stated range.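

In this assay, putting ethyl in place of acetyl on the core of compound 1 gave a 1.5-fold lower number from compound 1 to compound 4 (0.19 log units; within the scatter), so removing the acetyl from this place, meta to a large group and para to a methoxy group, left the number within the scatter. Among the compounds shown here, the same change therefore did not carry over in size or direction from one core to the other, and a step read on one core was a poor guide to the step on the other: the same change on two cores in this assay, a 3.2-fold higher number (0.50 log units; beyond the scatter) from compound 2 to compound 3 and a 1.5-fold lower number (0.19 log units; within the scatter) from compound 1 to compound 4, 4.9-fold (0.69 log units) apart, beyond the scatter of two such steps This comparison rests on only two pairs of compounds, and although the acetyl does not stand in the same place on the two cores, the pairs do not show that this difference in place accounts for the gap, nor how the change would behave on any further core.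

The compounds shown leave open how an amine, a carboxylic acid or a longer chain such as propyl would read in this assay in place of the acetyl on either core. They also leave open whether the difference between the two cores would persist in a read-out other than this antiproliferative one.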